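Extending the chain from compound 3 to compound 4

The source may hold more compounds than are shown below. What is called first, only, known or untested is meant among the compounds shown, and "the series" means these compounds.

The series shares one core and differs only in the length of a saturated chain. Tested in a functional assay on MCF7 cells (Homo sapiens) for antiproliferative activity, read by MTT assay, with a stated time of 48 h (a lower number here means a stronger inhibitor, a higher number a weaker inhibitor), compound 1 (`CCCCCCCn1cc(COC[C@@H]2OC[C@H](N)[C@H]2O)nn1`) reads > 128000 nM, which is a limit of the assay and not a number. In this assay, going by the values given here, compound 2 (`CCCCCCCCCCn1cc(COC[C@@H]2OC[C@H](N)[C@H]2O)nn1`) gives 45000 nM and sits well above compound 3 (`CCCCCCCCCCCCn1cc(COC[C@@H]2OC[C@H](N)[C@H]2O)nn1`) at 2620 nM, the lowest number so far.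

The next member is compound 4 (`CCCCCCCCCCCCCCn1cc(COC[C@@H]2OC[C@H](N)[C@H]2O)nn1`), reached through ethyl in place of hydrogen on a saturated chain carbon, ten or more bonds along the chain from an aromatic nitrogen on the chain. Among the compounds with values here, the closest precedent is the same ethyl in place of hydrogen one chain extension earlier, a large step: a 17-fold lower number from compound 2 to compound 3 (1.23 log units; beyond the scatter). Two further steps point the same way, though both start from a limit: an at least 2.8-fold lower number from compound 1 to compound 2 (0.45 log units; beyond the scatter) and an at least 48-fold lower number from compound 1 to compound 3 (1.68 log units; beyond the scatter).

Every measured extension has lowered the number, so a further fall in this assay is expected. Three compounds cannot show whether a fall of that size continues, so a smaller step than the last is assumed. The expected step is a 2.0-fold lower number from compound 3 to compound 4 (0.30 log units; within the scatter), modest and with a range that reaches back past no change. For compound 4 the estimated value is 1300 nM, with an expected range of 300 nM to 6000 nM.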

Compound 4, half-maximal inhibitory concentration: 2450 nM
Beside the measured number, compound 4's estimate is 1.9-fold (0.28 log units) below it; the range from low to high includes it.
By their numbers in this assay, from the lowest: compounds 4 and 3 (each within the scatter of the next); then compound 2. At a limit, above all of these: compound 1.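

The ethyl in place of hydrogen on a saturated chain carbon now gives a 1.1-fold lower number from compound 3 to compound 4 (0.03 log units; within the scatter) in this assay, against a 17-fold lower number from compound 2 to compound 3 (1.23 log units; beyond the scatter) for the same ethyl one extension earlier, so the large effect of extending the chain does not carry over to this last extension. Measured from the shorter members, the distance remains large, at an 18-fold lower number from compound 2 to compound 4 (1.26 log units; beyond the scatter) and an at least 52-fold lower number from compound 1 to compound 4 (1.71 log units; beyond the scatter), but compound 3 and compound 4 cannot be told apart, so the large distance from compound 2 is already reached at compound 3. The last of these steps starts from compound 1, whose reading is a limit and not a number: the limit of > 128000 nM in this assay, at which 1 of the 4 values shown sits.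

Two chain lengths within the scatter of each other cannot show whether the series has levelled off, so a longer chain could still give a lower number, the same number or a higher one. The series also leaves open what a group at the far end of the chain, such as an amine or a carboxylic acid, would do to the number at these lengths.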